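The compounds below may be only part of what the source reports. "The series", "measured", "known", "first", "only" and "open" are said of these compounds alone.

Measured compounds:
- Compound 2, `CC(C)(C)CNC(=O)C[C@H](NC(=O)C(C)(C)C)C(=O)N[C@@H](CCc1ccccc1)C(=O)NCc1ccccc1`: 62 nM in an assay on HEK293 cells for inhibition of nuclear factor NF-kappa-B complex (Homo sapiens), read by a luciferase reporter, with stated times of 1 h and 3 h; a higher number here means a weaker inhibitor, a lower number a stronger inhibitor
- Compound 1, `Cc1ccc(CNC(=O)[C@H](CCc2ccccc2)NC(=O)[C@H](CNC(=O)CC(C)(C)C)NC(=O)c2cc(C)on2)cc1`: "not determined" (no result reported) in this assay

Among the compounds with values here, compound 2 is the only compound with a number here, so it stands alone; compound 1 belongs to the same set but has no result to compare against. Within the data shown here, no pair of measured compounds differs in a single place, so no measured step is available to lean on.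

Compound 3, `CC(C)(C)CNC(=O)C[C@H](NC(=O)CCc1ccccc1)C(=O)N[C@@H](CCc1ccccc1)C(=O)NCc1ccccc1`, has not yet been measured. It differs from compound 2 in one place: phenethyl in place of tert-butyl on a carbonyl carbon. The shared core and the rest of the chain are unchanged.

Among the measured compounds shown here, with no measured step of this kind to guide the expectation, the size of the change is uncertain. The expectation is a small step, if any, in either direction, most likely within the usual scatter, with a modest weakening considered somewhat more plausible than a strengthening. Compound 3 is therefore estimated at 80 nM in this assay, with a range from 25 nM to 250 nM. That estimate means a step of a 1.3-fold higher number from compound 2 to compound 3 (0.11 log units; within the scatter).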

Compound 3, half-maximal inhibitory concentration: 12 nM
Compound 3: the middle estimate sits 6.7-fold (0.82 log units) above what was measured; measured number outside the range, below it.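

This position, on a carbonyl carbon whose other neighbour is an amide-type nitrogen, is sensitive to the group it carries: in this assay, phenethyl in place of tert-butyl gives a 5.2-fold lower number from compound 2 to compound 3 (0.71 log units; beyond the scatter) and so a stronger inhibitor. The change swaps 4 heavy atoms without a ring for 8 heavy atoms with a six-membered aromatic ring of carbon only, while neither group has any hydrogen-bond donors or acceptors, so those counts stay the same across the step. Nothing available here accounts for why this exchange lowers the number.

As far as these compounds go, with a single step, it remains open whether the aromatic ring, the length of the chain or the departure of tert-butyl matters most. Other groups on this carbonyl carbon could separate these possibilities: phenylpropyl would test a longer chain, cyclohexylethyl a saturated ring on a chain of the same length, and a plain ethyl group the chain without any ring.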